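The compounds below may be only part of what the source reports. "The series", "measured", "known", "first", "only" and "open" are said of these compounds alone.

Of the compounds shown here, three built on one shared core have been measured in a physicochemical assay for solubility, read by HPLC, at pH 6.8; on this read-out lower numbers stand for lower solubility and higher numbers for higher solubility. Compound 1 `CC(C)CN1CCCC[C@H]1C(=O)Nc1cc(C(C)(C)C)on1` gives 32 ug/mL. Compound 2 `CC(C)(C)c1cc(NC(=O)[C@@H]2CCCCN2CC2CCOCC2)no1` gives 72 ug/mL. Compound 3 `CC(C)(C)c1cc(NC(=O)[C@@H]2CCCCN2C(=O)C2CCS(=O)(=O)CC2)no1` gives 67 ug/mL. Within the data shown here, the only single-point step among them is a 2.3-fold higher number from compound 1 to compound 2 (0.35 log units; beyond the scatter), which arises from oxan-4-yl in place of isopropyl on a saturated chain carbon bound to the amine nitrogen in the ring.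

Compound 3 stands second highest of the three numbers in this assay. Its value and that of compound 2 lie within the scatter of each other, so no order can be claimed between them, while compound 3 sits higher than compound 1 by a margin beyond the scatter.

Compound 4 `CC(=O)N1CCN(C(=O)N2CCCC[C@H]2C(=O)Nc2cc(C(C)(C)C)on2)CC1` differs from compound 3 in one place: 4-acetylpiperazin-1-yl in place of 1,1-dioxothian-4-yl on a carbonyl carbon. Among the measured compounds shown here, no measured step changes a group on that carbonyl carbon; the one measured step, a 2.3-fold higher number from compound 1 to compound 2 (0.35 log units; beyond the scatter), concerns a different position and bears on this change only loosely, as a sign that swapping one saturated ring for another of similar size left this assay modestly altered. Compound 4 is therefore expected to show a step of a 1.0-fold higher number from compound 3 to compound 4 (0.02 log units; within the scatter), with no clear direction beyond the scatter. Compound 4 is estimated at 70 ug/mL, within a range of 30 ug/mL to 160 ug/mL.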

Compound 4, solubility: 62 ug/mL
Compound 4: middle estimate off by 1.1-fold (0.05 log units), on the high side, within the range that was stated.
By their numbers in this assay, from the lowest: compounds 1, 4, 3 and 2 (each within the scatter of the next, the first and the last beyond it).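

At this position, on a carbonyl carbon whose other neighbour is the amide-type nitrogen in a ring, replacing 1,1-dioxothian-4-yl with 4-acetylpiperazin-1-yl gives a 1.1-fold lower number from compound 3 to compound 4 (0.03 log units; within the scatter) in this assay, the first step measured at this place. The two groups are not alike in what can be counted: the entering group has no sulfur but has nitrogen in its ring, along with fewer double bonds outside aromatic rings and fewer hydrogen-bond acceptors, yet this single pair shows no difference that the read-out can separate from the scatter. Nothing available explains this outcome for compound 3 and compound 4.

The compounds shown leave open whether a different kind of group on this carbonyl carbon, such as a carboxylic acid on a short chain or a primary amine, would give a step beyond the scatter in this assay. They also leave open whether the same replacement of 1,1-dioxothian-4-yl with 4-acetylpiperazin-1-yl would read alike on a different core.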